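The source may report more compounds than this note shows. Statements on the series, on what has been measured and on what is new or still open speak of the compounds shown alone.

Measured so far:
- compound 1, `c1coc(-c2ccccc2OCC2=NCCN2)c1`: 110%
- compound 2, `c1ccc(-c2cc[nH]n2)c(OCC2=NCCN2)c1`: 39%

In a functional assay for activation of Alpha-1B adrenergic receptor (Homo sapiens), read by calcium flux (on this read-out higher numbers stand for larger maximal responses and lower numbers for smaller maximal responses), compound 1 gives 110% and compound 2 gives 39%. Within the data shown here, compound 2 therefore stands lowest of the two, with compound 1 as its only neighbour, and the one measured step, a number 71 percentage points lower from compound 1 to compound 2 (beyond the scatter), shows how much a swap of one five-membered aromatic ring for another at this place can matter. Compound 3, `c1ccc(-c2ccns2)c(OCC2=NCCN2)c1`, differs from compound 2 by 1,2-thiazol-5-yl in place of 1H-pyrazol-3-yl on an aromatic carbon. Among the measured compounds shown here, only that single step bears on the new change, and it involves a different ring pair, so it is a loose guide at best; it suggests that the maximal response can move widely in either direction. On balance a rise is expected, a number 36 percentage points higher from compound 2 to compound 3 (beyond the scatter), with wide uncertainty. For compound 3 the expected value in this assay is 75%, within 30% to 115%.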

Compound 3, largest response reached (reported as maximum), in percent of the reference or control that the assay uses: 56%
For compound 3 the middle estimate is 19 percentage points above the measured one, and the stated range covers the measured number.
By their numbers in this assay, from the lowest: compound 2; then compound 3; then compound 1.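

In this assay, 1,2-thiazol-5-yl on the aromatic carbon gives a number 17 percentage points higher from compound 2 to compound 3 (beyond the scatter) when it replaces 1H-pyrazol-3-yl and a number 54 percentage points lower from compound 1 to compound 3 (beyond the scatter) when it replaces furan-2-yl. This place thus now shows three separate levels of maximal response, with the new ring standing between the other two. The 1,2-thiazol-5-yl and 1H-pyrazol-3-yl groups are both five-membered aromatic rings with 2 hetero atoms and the same count of heavy atoms, so the response here can shift even when those counts stay the same. Nothing measured here explains these differences.

On these data alone, it remains open how the response would change with an open-chain group at this place, such as an amine or a carboxylic acid. As far as these compounds go, the effect of a six-membered ring such as pyridine is equally open.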